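The compounds below may be only part of what the source reports. "The series", "measured", "known", "first", "only" and "open" are said of these compounds alone.

- Compound 1 `Cc1ccc(S(=O)(=O)Oc2cccc3c2C(=O)C=CC3=O)cc1`: 9470 nM
- Compound 2 `COc1ccc2c(c1)C(=O)C=CC2=O`: 22700 nM

In a functional assay on HeLa cells (Homo sapiens) for cytotoxicity (a lower number here means a stronger inhibitor, a higher number a weaker inhibitor), compound 2 has the higher of the two numbers, at 22700 nM, which makes it the weaker inhibitor. Compound 1 lies lower at 9470 nM, and that gap is beyond the scatter.

The next compound, compound 3 `O=C1C=CC(=O)c2cc(Oc3ccco3)ccc21`, is built from compound 2 with one change: furan-2-yl in place of methyl on an oxygen on an aromatic ring, (furan-2-yl in place of methyl on an oxygen on an aromatic ring). Its number in this assay is not yet known.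

Among the measured compounds shown here, no step between two measured compounds is available as a guide, so any forecast rests on thin ground. Compound 1, at 9470 nM, carries a larger group on an oxygen than compound 2 does and has the lower number, but these two compounds differ in more than one place. A modest step towards a lower number is therefore expected, and a result within the scatter of compound 2 would be no surprise. The estimated change is a 2.1-fold lower number from compound 2 to compound 3 (0.31 log units; beyond the scatter). For compound 3 the expected value is 11000 nM, with an estimated range of 3500 nM to 30000 nM.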

Compound 3, half-maximal inhibitory concentration: 17200 nM
For compound 3 the middle estimate is 1.6-fold (0.19 log units) below the measured one, within the range that was stated.
By their numbers in this assay, from the lowest: compounds 1, 3 and 2 (each within the scatter of the next, the first and the last beyond it).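

On the oxygen on the aromatic ring, replacing methoxy with (furan-2-yl)oxy gives, in this assay, a 1.3-fold lower number from compound 2 to compound 3 (0.12 log units; within the scatter), so compound 2 and compound 3 cannot be told apart in this assay. Among the compounds shown here, this is the first comparison in the set that changes only one place. Compound 1 differs from compound 2 in more than one place and could not provide such a comparison. The comparison of compound 2 and compound 3 shows that a furan-2-yl group of 5 heavy atoms, with its five-membered aromatic ring, can take the place of a single methyl without a readable change in the number. No available measurement offers an explanation for this result.

From the compounds shown here alone, whether an amine, a carboxylic acid or a longer alkyl chain on this same oxygen would shift the number beyond the scatter remains open. Going by these compounds, it is also open whether a phenyl ring would match furan-2-yl here, and whether the same replacement would give a similar result at another place on the shared core.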